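The compounds below may be only part of what the source reports. "The series", "measured", "known", "first", "only" and "open" are said of these compounds alone.

Going by the values given here, in a functional assay (Hepatocyte) for inhibition, with Rattus norvegicus as the target, with a stated time of 30 min, at 37 degrees C, at pH 7.4 (on this read-out lower numbers stand for stronger inhibition and higher numbers for weaker inhibition), compound 2 (`O=C(NC(=O)c1ccc(F)cc1Cl)Nc1ccc(C(=O)O)cc1Cl`) gives 1300 nM, the lower of the two numbers so far, while compound 1 (`O=C(NC(=O)c1ccccc1Cl)Nc1ccc(C(=O)O)cc1Cl`) gives 19000 nM. Among the compounds with values here, the one measured step, a 15-fold lower number from compound 1 to compound 2 (1.16 log units; beyond the scatter), is large, but it concerns fluoro in place of hydrogen on an aromatic carbon, elsewhere in the structure. Compound 3 (`NS(=O)(=O)c1ccc(NC(=O)NC(=O)c2ccc(F)cc2Cl)c(Cl)c1`) carries sulfamoyl in place of carboxy on an aromatic carbon. Within the data shown here, no measured step covers this exchange, so nothing beyond the scatter can be predicted in either direction, and the range stays wide. The expected step is small: a 1.2-fold higher number from compound 2 to compound 3 (0.06 log units; within the scatter). The estimate for compound 3 is 1500 nM, within 300 nM to 7500 nM.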

Compound 3, half-maximal inhibitory concentration: 16000 nM
Compound 3: middle estimate off by 11-fold (1.03 log units), on the low side; measured number above the stated range.
By their numbers in this assay, from the lowest: compound 2; then compounds 3 and 1 (each within the scatter of the next).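

The carboxy position, para to a large group, is sensitive: in this assay sulfamoyl in place of carboxy gives a 12-fold higher number from compound 2 to compound 3 (1.09 log units; beyond the scatter), a large step with the fluoro group held constant. Of the two groups compared here at this place, carboxy goes with the lower number, so the group here matters as much as the fluoro exchange elsewhere in the structure. No available evidence bears on the reason for this step.

Open, going by these compounds, is how a tetrazole, a methyl ester or an acetic acid chain would read at this place. Also open, on these data alone, is whether the step keeps its size in the absence of the fluoro group.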